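From trifluoromethyl to dimethylamino on a Z double bond

This account rests on a few compounds, and the source may have more. Where it says the series, first, only, none or still open, it means among the compounds named here.

Compound 1 `FC(F)(F)c1ccc(/C=C/c2ccc3ccccc3c2)cc1` gives > 5000 nM in a functional assay on A549 cells (Homo sapiens) for inhibition; on this read-out higher numbers stand for weaker inhibition and lower numbers for stronger inhibition
Compound 2 `FC(F)(F)c1ccc(/C=C\c2ccc3ccccc3c2)cc1` gives > 5000 nM in this assay

Both entries are limits and not numbers. Compound 2 stands at > 5000 nM as a limit, so it cannot be given a rank in this assay against compound 1. Going by the values given here, the one measured step is a step that the two limits leave unreadable from compound 1 to compound 2; it rests on the limit of > 5000 nM in this assay, at which 2 of the 2 values shown sit, and on (the fact that compounds 1 and 2 differ only in the configuration as drawn), so it gives no size for the group that changes next.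

Compound 3 `CN(C)c1ccc(/C=C\c2ccc3ccccc3c2)cc1` differs from compound 2 by dimethylamino in place of trifluoromethyl on an aromatic carbon, para to a large group: dimethylamino in place of trifluoromethyl on an aromatic carbon. Among the compounds with values here, no measured step touches this place, so the data offer no size to carry over. The expectation rests only on compound 2, whose > 5000 nM is a limit. Somewhat stronger inhibition is expected, although another limit is about as likely as a number. The expected change, loosely estimated, is an at least 1.6-fold lower number from compound 2 to compound 3 (0.22 log units; that floor lies within the scatter) in this assay. For compound 3 the estimate is 3000 nM, with an expected range from 300 nM to 10000 nM.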

Compound 3, half-maximal inhibitory concentration: 3660 nM
The estimate for compound 3 lay 1.2-fold (0.09 log units) below the measured number; low and high end bracket the measured number.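

Compound 3 is the only one of the three shown that gives a number and not a limit: in this assay compound 3 gives 3660 nM. So with dimethylamino in place of trifluoromethyl on an aromatic carbon, para to a large group, the Z compound comes into the measurable range, and the change reads as an at least 1.3-fold lower number from compound 2 to compound 3 (0.13 log units; that floor lies within the scatter). Going by these compounds, that floor does not by itself establish a change beyond the scatter, and the true size of the step stays open, as compound 2 holds a limit and not a number: the limit of > 5000 nM in this assay, at which 2 of the 3 values shown sit.

Whether the Z double bond matters for this value stays open, as the only pair shown that differs in configuration gives no readable step and no E counterpart of compound 3 stands among the compounds shown: the fact that compounds 1 and 2 differ only in the configuration as drawn. On these data alone, it is also open how far this place tolerates other groups, for instance whether a primary amine, a methoxy group or a longer chain such as diethylamino would give a number close to that of compound 3 or a clearly different one.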